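Chloro for trifluoromethyl in a weakly active series

The compounds below may be only part of what the source reports. "The series", "measured", "known", "first", "only" and "open" are said of these compounds alone.

In a functional assay on HCT-116 cells (Homo sapiens) for antiproliferative activity, read by MTT assay, with a stated time of 24 h (a lower number here means a stronger inhibitor, a higher number a weaker inhibitor), compound 1 (`COc1ccc(/C=C/C(=O)c2ccc(OC)c3c2OC(C)(C)C=C3)c(F)c1`) gives > 10000 nM, which is a limit of the assay and not a number. Compound 2 (`COc1ccc(C(=O)/C=C/c2ccc(N3CCCC3)cc2)c2c1C=CC(C)(C)O2`) gives a true number, 8590 nM. Compound 3 (`COc1ccc(C(=O)/C=C/c2ccc(C(F)(F)F)cc2)c2c1C=CC(C)(C)O2`) stands at > 10000 nM, again only a limit. Compound 4 (`COc1ccc(C(=O)/C=C/c2ccc(Cl)cc2)c2c1C=CC(C)(C)O2`) carries chloro in place of trifluoromethyl on an aromatic carbon. Within the data shown here, the one measured step at this place is an at least 1.1-fold higher number from compound 2 to compound 3 (0.06 log units; that floor lies within the scatter), so even replacing trifluoromethyl with pyrrolidin-1-yl gave no change beyond the scatter. The expected change is therefore small, with a number no higher from compound 3 to compound 4 (the limit leaves the size open) estimated and no step beyond the scatter foreseen. Compound 4 is expected to lie near 10000 nM, with an estimated range from 4000 nM to 25000 nM.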

Compound 4, half-maximal inhibitory concentration: > 10000 nM
Compound 4: only a limit was reported; the forecaster's own chance of this, stated with the estimate: 60%; the middle value sits exactly at the limit.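

In this assay, chloro, with a single heavy atom, sits at the same limit as trifluoromethyl on this aromatic carbon, so neither group gives a true number here: the limit of > 10000 nM in this assay, at which 3 of the 4 values shown sit.

Chloro in place of pyrrolidin-1-yl gives an at least 1.1-fold higher number from compound 2 to compound 4 (0.06 log units; that floor lies within the scatter). The steps from compound 3 and from compound 1 to compound 4 join two limits and cannot be read.

As far as these compounds go, whether a carboxylic acid or a hydroxyl group at this position would give a true number stays open. From the compounds shown here alone, how far the real values of compound 3 and compound 4 lie beyond the limit also stays open.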